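A few compounds are considered here, and "the series" means these few. Any claim that something is new, unique, unknown or untested is made for them only; others in the source may bear on it.

Of the compounds shown here, two have numbers so far in a functional assay on UACC-257 cells (Homo sapiens) for antiproliferative activity, read by sulforhodamine B assay, with a stated time of 48 h (a higher number here means a weaker inhibitor, a lower number a stronger inhibitor), and there compound 1 `O=C(NCCCNc1cc(-c2cn(-c3ccccc3)nc2-c2cccc(O)c2)ccn1)Nc1ccc(F)cc1` gives 3070 nM as one of them. Going by the values given here, its sole neighbour, compound 2 `O=C(NCCCNc1cc(-c2cn(-c3ccccc3)nc2-c2cccc(O)c2)ccn1)Nc1cccc(C(F)(F)F)c1` with 4800 nM on the same scale, stands within the scatter of it, so the two cannot be told apart. Compound 3 `COc1cccc(-c2nn(-c3ccccc3)cc2-c2ccnc(NCCCNC(=O)Nc3ccc(F)cc3)c2)c1` departs from compound 1 by methyl in place of hydrogen on an oxygen on an aromatic ring in the shared core, that is, methyl in place of hydrogen on an oxygen on an aromatic ring, or 3-hydroxyphenyl to 3-methoxyphenyl. Among the compounds with values here, the one measured step is a 1.6-fold higher number from compound 1 to compound 2 (0.19 log units; within the scatter) and it comes with 3-(trifluoromethyl)phenyl in place of 4-fluorophenyl on an amide-type nitrogen, a different place from this oxygen. Within the data shown here, no measured pair tests hydroxy to methoxy directly. Among the measured compounds shown here, that single small step is the only guide, so no change beyond the scatter is expected in this assay and any lean towards a higher number would be slight. The estimated change is a 1.3-fold higher number from compound 1 to compound 3 (0.11 log units; within the scatter) and it remains only an expectation. For compound 3 the expected value is 4000 nM with an estimated range from 1700 nM to 9500 nM as the likely span.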

Compound 3, half-maximal inhibitory concentration: 7050 nM
Compound 3: the middle estimate sits 1.8-fold (0.25 log units) below what was measured; low and high end bracket the measured number.
By their numbers in this assay, from the lowest: compounds 1, 2 and 3 (each within the scatter of the next, the first and the last beyond it).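

In this assay, going by these compounds alone, the change from 3-hydroxyphenyl to 3-methoxyphenyl gives a 2.3-fold higher number from compound 1 to compound 3 (0.36 log units; beyond the scatter), the first step to lie beyond the scatter, though only modestly. Within the data shown here, this shows that the oxygen on the aromatic ring is a place where a single added methyl can move the number measurably, which the one earlier step, made elsewhere on an amide-type nitrogen, could not show. Nothing at hand bears on the cause of this shift.

The compounds shown leave open whether the loss of the hydrogen or the presence of the methyl matters here, a question that an amino group or a fluorine in place of the hydroxy, or an ethyl in place of the methyl, would help to separate. They also leave open whether hydroxy to methoxy gives a step of similar size when 3-(trifluoromethyl)phenyl rather than 4-fluorophenyl sits on the amide-type nitrogen, and whether the step holds outside this single cell line.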